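A Smaller Group Replaces the Fluorinated Alcohol

The source may hold more compounds than are shown below. What is called first, only, known or untested is meant among the compounds shown, and "the series" means these compounds.

Of the compounds shown here, two built on the same sulfonamide-piperazine core have been measured. Compound 1 `CC#C[C@H]1CN(S(=O)(=O)c2ccc(N)nc2)CCN1c1ccc(C(O)(COC)C(F)(F)F)cc1` gives 202 nM in an assay on cells (Hepatocyte) for inhibition of glucokinase regulatory protein (Mus musculus), with stated times of 20 min and 40 min; a lower number here means that less compound is needed, a higher number that more compound is needed for the effect. Compound 2 `CC#C[C@H]1CN(S(=O)(=O)c2ccc(N)nc2)CCN1c1ncc(C(O)(C(F)(F)F)C(F)(F)F)cn1` gives 2200 nM in this assay, so compound 1 stands as the lower of the two numbers, with compound 2 sitting higher by a distance that lies beyond the usual scatter. Compound 2 differs from compound 1 in more than one place, so its gap cannot be tied to a single change.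

Compound 3 `CC#C[C@H]1CN(S(=O)(=O)c2ccc(N)nc2)CCN1c1ccc([S+](C)[O-])cc1` is the next candidate. It differs from compound 1 in one place: a group of 3 heavy atoms (1 carbon, 1 oxygen, 1 sulfur; no ring) in place of a group of 9 heavy atoms (4 carbon, 2 oxygen, 3 fluorine; no ring), on an aromatic carbon. The group that leaves carried a hydrogen-bond donor; the group that enters carries none, and it is much smaller. Within the data shown here, no measured pair shows this kind of swap, so the direction is uncertain. With less to hold onto, compound 3 is expected to need somewhat more compound than compound 1, a step of a 2.0-fold higher number from compound 1 to compound 3 (0.30 log units; within the scatter) that may only just exceed the scatter. Compound 3 is therefore estimated at 400 nM, with a range from 100 nM to 1500 nM.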

Compound 3, half-maximal effective concentration: > 12500 nM
Compound 3 gave a limit, no number; the forecaster's own chance of this, stated with the estimate: 5%; at least 31-fold (1.49 log units) between middle value and limit.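

Compound 3 gives a limit, not a number, in this assay: the limit of > 12500 nM in this assay, at which 1 of the 3 values shown sits.

Placing the group of 3 heavy atoms on the aromatic carbon, para to a large group, in place of the group of 9 heavy atoms gives an at least 61-fold higher number from compound 1 to compound 3 (1.79 log units; beyond the scatter), a large step that ties a clear loss in this assay to a change in one place, which compound 2 could not do because it differs from compound 1 in more than one place. The position is therefore not indifferent to what it carries, and this one swap costs far more than the small step that a change of this kind might have suggested. The swap removes the hydrogen-bond donor and most of the heavy atoms together, so this single step cannot say which of the two matters.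

The compounds shown leave open whether a small group that keeps a donor, such as a hydroxyl or an amine, would hold the value of compound 1 at this position. They also leave open which part of the group in compound 1 counts, since a simple tertiary alcohol without trifluoromethyl or without the methoxymethyl chain is not among them.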